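Swapping the Halogenated Ring for a Methylphenyl Group

The compounds below may be only part of what the source reports. "The series", "measured", "known", "first", "only" and "open" are said of these compounds alone.

In a functional assay on A-431 cells (Homo sapiens) for antiproliferative activity, read by MTT assay, with a stated time of 72 h (a higher number here means a weaker inhibitor, a lower number a stronger inhibitor), compound 3 `NS(=O)(=O)c1ccc(NC(=S)Nc2ccc3ncnc(Nc4ccc(F)c(Cl)c4)c3c2)cc1` gives 37600 nM, the highest number among the three measured compounds. Compound 1 `COc1ccc(Nc2ncnc3cc(OC)c(OCCCCC(=O)Nc4ccc(S(N)(=O)=O)cc4)cc23)cc1OC` gives 35400 nM, which lies within the usual scatter of compound 3, while compound 2 `COc1cc2ncnc(Nc3ccc(F)c(Br)c3)c2cc1OCCCCC(=O)Nc1ccc(S(N)(=O)=O)cc1` gives 8020 nM and is clearly the stronger inhibitor of the three. Going by the values given here, the one measured single-point step, a 4.4-fold lower number from compound 1 to compound 2 (0.64 log units; beyond the scatter), shows that the group on this ring nitrogen can move the number well beyond the scatter. Compound 4 `Cc1ccc(Nc2ncnc3ccc(NC(=S)Nc4ccc(S(N)(=O)=O)cc4)cc23)cc1` arises from compound 3 by 4-methylphenyl in place of 3-chloro-4-fluorophenyl on a nitrogen on an aromatic ring. Since a halogenated ring of this kind is what made compound 2 stronger in a 4.4-fold lower number from compound 1 to compound 2 (0.64 log units; beyond the scatter), removing it is expected to weaken inhibition. The expected step is a 1.7-fold higher number from compound 3 to compound 4 (0.24 log units; within the scatter). Compound 4 is thus estimated at 65000 nM, ranging from 25000 nM to 170000 nM.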

Compound 4, half-maximal inhibitory concentration: 40000 nM
Estimate against measurement, compound 4: 1.6-fold (0.21 log units) above; measured number inside the range.
By their numbers in this assay, from the lowest: compound 2; then compounds 1, 3 and 4 (each within the scatter of the next).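

In this assay there is a 1.1-fold higher number from compound 3 to compound 4 (0.03 log units; within the scatter), so on this nitrogen 4-methylphenyl and 3-chloro-4-fluorophenyl cannot be told apart on the core of compound 3. The earlier step, a 4.4-fold lower number from compound 1 to compound 2 (0.64 log units; beyond the scatter), went beyond the scatter on a different core, so a change of ring at this place does not always move the number. Nothing measured here accounts for this difference between the two steps.

As far as these compounds go, it remains open whether 3-bromo-4-fluorophenyl would lower the number on the core of compound 3. Also open, from the compounds shown here alone, is how a plain phenyl ring or a 3-ethynylphenyl ring would behave on this nitrogen.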